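A few compounds are considered here, and "the series" means these few. Any claim that something is new, unique, unknown or untested is made for them only; others in the source may bear on it.

Going by the values given here, compound 1 `COc1cc(-c2nnc3n2NC(c2ccco2)C(C(=O)c2ccccc2C)S3)cc(OC)c1OC` is the only compound of this set with a number in a functional assay on PC-3 cells (Homo sapiens) for cytotoxicity, read by MTT assay, with a stated time of 48 h; on this read-out lower numbers stand for stronger inhibition and higher numbers for weaker inhibition; there compound 1 gives 88400 nM. Compound 2 `COc1ccc(C(=O)C2Sc3nnc(-c4cc(OC)c(OC)c(OC)c4)n3NC2c2ccco2)cc1` is the other measured member. In this assay compound 2 is reported only as a limit, > 100000 nM. Between the two lies one step, an at least 1.1-fold higher number from compound 1 to compound 2 (0.05 log units; that floor lies within the scatter), in which 4-methoxyphenyl replaces 2-methylphenyl on a carbonyl carbon; that one of the two values sits at a limit is recorded by the limit of > 100000 nM in this assay, at which 1 of the 2 values shown sits. Compound 3 `COc1cccc(C(=O)C2Sc3nnc(-c4cc(OC)c(OC)c(OC)c4)n3NC2c2ccco2)c1` differs from compound 1 at the same place: 3-methoxyphenyl in place of 2-methylphenyl on a carbonyl carbon. Among the compounds with values here, the only measured step that bears on this change is the one from compound 1 to compound 2, and it is too small to mark a direction. Compound 3 is therefore expected to sit near compound 1 in this assay. The expected step is a 1.2-fold higher number from compound 1 to compound 3 (0.09 log units; within the scatter), and a limit rather than a number is quite possible. The estimate for compound 3 is 110000 nM, expected between 45000 nM and 270000 nM.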

Compound 3, half-maximal inhibitory concentration: 84600 nM
Estimate against measurement, compound 3: 1.3-fold (0.11 log units) above; low and high end bracket the measured number.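

In this assay the change at this place can now be read between two numbers rather than against a limit (a 1.0-fold lower number from compound 1 to compound 3 (0.02 log units; within the scatter)), so 3-methoxyphenyl and 2-methylphenyl on a carbonyl carbon cannot be told apart here. The two methoxyphenyl groups cannot be separated either (an at least 1.1-fold lower number from compound 2 to compound 3 (0.07 log units; that floor lies within the scatter)), so the compounds give no sign that the place of the methoxy group on the ring matters. Compound 2 still stands as a limit and not as a number: the limit of > 100000 nM in this assay, at which 1 of the 3 values shown sits.

All three compounds keep a six-membered aromatic ring of carbon only on the carbonyl carbon, and none of the changes shown moves the value beyond the scatter. On these data alone, whether an amine or a carboxylic acid on that ring, or a longer chain in its place, would do so stays open.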